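Moving the methoxy groups: from one to two on the amide aryl

The source may hold more compounds than are shown below. What is called first, only, known or untested is meant among the compounds shown, and "the series" means these compounds.

Of the compounds shown here, three sharing one core have been tested in a functional assay on A549 cells (Homo sapiens) for antiproliferative activity, read by CCK-8 assay, with a stated time of 72 h; a higher number here means a weaker inhibitor, a lower number a stronger inhibitor. Compound 1 `COc1cccc(OC)c1C(=O)Nc1ccc(C(=O)/C=C/c2nc(C)c(C)nc2C)cc1` gives 8470 nM, compound 2 `Cc1nc(C)c(/C=C/C(=O)c2ccc(NC(=O)c3ccc(F)cc3F)cc2)nc1C` gives 2450 nM, and compound 3 `COc1ccc(C(=O)Nc2ccc(C(=O)/C=C/c3nc(C)c(C)nc3C)cc2)cc1` gives 4150 nM. Compound 3 stands second highest of these three numbers: the nearer step is a 1.7-fold higher number from compound 2 to compound 3 (0.23 log units; within the scatter), while the further step is a 2.0-fold lower number from compound 1 to compound 3 (0.31 log units; beyond the scatter).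

Compound 4 `COc1cc(OC)cc(C(=O)Nc2ccc(C(=O)/C=C/c3nc(C)c(C)nc3C)cc2)c1` differs from compound 3 in one place: 3,5-dimethoxyphenyl in place of 4-methoxyphenyl on a carbonyl carbon. The closest measured comparison is the step from a ring with two methoxy groups to one with a single methoxy group, a 2.0-fold lower number from compound 1 to compound 3 (0.31 log units; beyond the scatter), which went toward a lower number. Going by the values given here, compound 4 reverses the count of methoxy groups, though in a different arrangement, so a modest shift toward a higher number in this assay is expected, likely no larger than that step. The estimate for compound 4 is therefore 5500 nM, between 2200 nM and 13000 nM, which would mean an expected step of a 1.3-fold higher number from compound 3 to compound 4 (0.12 log units; within the scatter).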

Compound 4, half-maximal inhibitory concentration: 10200 nM
For compound 4 the middle estimate is 1.9-fold (0.27 log units) below the measured one, within the range that was stated.
By their numbers in this assay, from the lowest: compounds 2 and 3 (each within the scatter of the next); then compounds 1 and 4 (each within the scatter of the next).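

In this assay, going by these compounds alone, compound 4 shows that a second methoxy group on this ring, attached to the carbonyl carbon of the amide, gives a weaker result than the single methoxy group of compound 3 in a new arrangement too (a 2.5-fold higher number from compound 3 to compound 4 (0.39 log units; beyond the scatter)), and the two dimethoxyphenyl arrangements cannot be told apart (a 1.2-fold higher number from compound 1 to compound 4 (0.08 log units; within the scatter)) in this assay. Set against the 2,4-difluorophenyl ring, the 3,5-dimethoxyphenyl ring also gives a weaker result (a 4.2-fold higher number from compound 2 to compound 4 (0.62 log units; beyond the scatter)) at this position. Nothing shown here gives a reason for these shifts.

The compounds shown carry only methoxy groups or fluorine atoms on this ring, so the effect of an amine, a carboxylic acid or a longer chain such as butoxy remains open. As far as these compounds go, whether a third methoxy group would continue the shift also remains open.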